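Compound 3 loses its tert-butoxycarbonyl group

This account rests on a few compounds, and the source may have more. Where it says the series, first, only, none or still open, it means among the compounds named here.

Measured in an ADME assay on microsomes from liver (Homo sapiens) for metabolic stability, read by LC-MS, using NADPH, tested at 1 uM; on this read-out lower numbers stand for a shorter-lived compound and higher numbers for a longer-lived compound:
Compound 1 `CCOC(=O)NC/C=C\CN(C)C[C@H]1O[C@@H](n2c(C)nc3c(N)ncnc32)[C@H](O)[C@@H]1O`: > 1.5 h (a limit)
Compound 2 `Cc1nc2c(N)ncnc2n1[C@@H]1O[C@H](CN(C)C/C=C\CNC(=O)OC(C)(C)C)[C@H]2OC(C)(C)O[C@H]21`: < 0.0417 h (a limit)
Compound 3 `Cc1nc2c(N)ncnc2n1[C@@H]1O[C@H](CN(C/C=C\CNC(=O)OC(C)(C)C)C2CC2)[C@H]2OC(C)(C)O[C@H]21`: < 0.0417 h (a limit)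

Compound 3 stands at the short-lived end of this assay, and its < 0.0417 h is a limit, not a number. Compound 4 `Cc1nc2c(N)ncnc2n1[C@@H]1O[C@H](CN(C/C=C\CN)C2CC2)[C@H]2OC(C)(C)O[C@H]21` differs from it by hydrogen in place of tert-butoxycarbonyl on an amine nitrogen. Among the compounds with values here, the one measured step, a step that the two limits leave unreadable from compound 2 to compound 3, concerns cyclopropyl in place of methyl on an amine nitrogen and sets no size for this change. Within the data shown here, no measured step removes this group. Compound 3 sits at a limit of < 0.0417 h, so only a rise could be read. A modest rise is expected, an at least 1.9-fold higher number from compound 3 to compound 4 (0.28 log units; that floor lies within the scatter). For compound 4 the estimate is 0.08 h, with an expected range of 0.03 h to 0.4 h.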

Compound 4, half-life: > 1.5 h
Compound 4 gave a limit, no number; the forecaster's own chance of this, stated with the estimate: 45%; middle value at least 18-fold (1.27 log units) away from the limit.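

Hydrogen in place of tert-butoxycarbonyl on an amine nitrogen gives the first step of readable size in this assay: an at least 35-fold higher number from compound 3 to compound 4 (1.55 log units; beyond the scatter). Compound 4 keeps the cyclopropyl group, so cyclopropyl on this amine does not by itself hold a compound at the short-lived end. Compound 4 gives a limit of the assay, not a number: the limit of > 1.5 h in this assay, at which 2 of the 4 values shown sit.

Going by these compounds, the step from methyl to cyclopropyl still cannot be read, and the full size of the rise remains unknown. Also open, on these data alone, is how an acetyl or a methyl group on this amine nitrogen would read.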